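From pyridin-4-yl to 4-methylpiperazin-1-yl on a shared core

This account rests on a few compounds, and the source may have more. Where it says the series, first, only, none or still open, it means among the compounds named here.

In a functional assay on HepG2 cells (Homo sapiens) for inhibition, read by MTT assay, with a stated time of 72 h (on this read-out higher numbers stand for weaker inhibition and lower numbers for stronger inhibition), compound 1 (`CC(C)(C)n1cc2c(n1)C(=O)CC1(CCN(C(=O)c3cc(-c4ccc(Cl)cc4)nc4ccccc34)CC1)O2`) gives 630 nM, compound 2 (`CC(C)(C)n1cc2c(n1)C(=O)CC1(CCN(C(=O)c3cc(-c4ccc(F)cc4)nc4ccccc34)CC1)O2`) gives 2930 nM and compound 3 (`CC(C)(C)n1cc2c(n1)C(=O)CC1(CCN(C(=O)c3cc(-c4ccncc4)nc4ccccc34)CC1)O2`) gives 380 nM. Compound 3 therefore cannot be separated from the chloro member of the set, as shown by a 1.7-fold lower number from compound 1 to compound 3 (0.22 log units; within the scatter), but it stands clear of the fluoro member, as shown by a 7.7-fold lower number from compound 2 to compound 3 (0.89 log units; beyond the scatter). The next change, leading to compound 4 (`CN1CCN(c2cc(C(=O)N3CCC4(CC3)CC(=O)c3nn(C(C)(C)C)cc3O4)c3ccccc3n2)CC1`), is 4-methylpiperazin-1-yl in place of pyridin-4-yl on an aromatic carbon. It places 4-methylpiperazin-1-yl in place of pyridin-4-yl on an aromatic carbon, next to the ring nitrogen. Among the measured compounds shown here, no measured step brings a non-aromatic ring to this carbon, so the evidence is indirect. Even fluoro in place of chloro gave a 4.7-fold higher number from compound 1 to compound 2 (0.67 log units; beyond the scatter), which suggests that a larger replacement could produce a step of modest size in this assay. The direction is uncertain, though a higher number is more likely. The expected step is a 2.4-fold higher number from compound 3 to compound 4 (0.37 log units; beyond the scatter). For compound 4, the estimated value is 900 nM, with an expected range from 200 nM to 4000 nM.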

Compound 4, half-maximal inhibitory concentration: 9550 nM
For compound 4 the middle estimate is 11-fold (1.03 log units) below the measured one, and the stated range ends below it.
By their numbers in this assay, from the lowest: compounds 3 and 1 (each within the scatter of the next); then compound 2; then compound 4.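

At the aromatic carbon next to the ring nitrogen, 4-methylpiperazin-1-yl is the only non-aromatic ring among the four compounds, and in this assay it gives a 25-fold higher number from compound 3 to compound 4 (1.40 log units; beyond the scatter), the largest step in the set. The change is also large against the chloro member, a 15-fold higher number from compound 1 to compound 4 (1.18 log units; beyond the scatter), and modest against the fluoro member, a 3.3-fold higher number from compound 2 to compound 4 (0.51 log units; beyond the scatter), so every step to the non-aromatic ring is beyond the scatter and leads to a higher number. The earlier steps shown here had exchanged only aromatic rings here, and this one shows that the read-out also responds to the kind of ring at this carbon.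

Nothing available explains the size of this step. From the compounds shown here alone, it remains open whether the non-aromatic ring itself or its methyl-bearing nitrogen sets the result, and how a morpholine or a dimethylamino group would read at this carbon.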